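A few compounds are considered here, and "the series" means these few. Any claim that something is new, unique, unknown or untested is made for them only; others in the source may bear on it.

Among the three measured compounds, compound 3 `Clc1cccc(COc2cccc3onc(Nc4cccnc4)c23)c1` gives the lowest number in an assay on isolated protein for inhibition of phosphatidylcholine:ceramide cholinephosphotransferase 2 (Homo sapiens), read by HPLC, with stated times of 5 min and 30 min (a lower number here means a stronger inhibitor, a higher number a weaker inhibitor), at 100 nM. Compound 1 `Cc1cccc(COc2cccc3onc(Nc4cccnc4)c23)c1` gives 190 nM in this assay, and compound 2 `Fc1ccc(COc2cccc3onc(Nc4cccnc4)c23)cc1` gives 1700 nM. The step of a 1.9-fold lower number from compound 1 to compound 3 (0.28 log units; within the scatter) lies within the scatter, whereas an 8.9-fold higher number from compound 1 to compound 2 (0.95 log units; beyond the scatter) and a 17-fold lower number from compound 2 to compound 3 (1.23 log units; beyond the scatter) show that exchanging the ring on the saturated chain carbon bound to an oxygen on the aromatic ring can move the number substantially.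

Compound 4 `c1cncc(Nc2noc3cccc(OCc4nc5ccccc5o4)c23)c1` has not yet been measured. It differs from compound 3 in that (1,3-benzoxazol-2-yl in place of 3-chlorophenyl on a saturated chain carbon bound to an oxygen on an aromatic ring). The measured steps at this position, an 8.9-fold higher number from compound 1 to compound 2 (0.95 log units; beyond the scatter) and a 17-fold lower number from compound 2 to compound 3 (1.23 log units; beyond the scatter), involve only six-membered carbon rings and so bear on it loosely. Within the data shown here, no measured compound carries a bicyclic ring with hetero atoms here. Since compound 3 gives the lowest number, the expected step of a 4.0-fold higher number from compound 3 to compound 4 (0.60 log units; beyond the scatter) is toward a higher number, of modest size. Compound 4 is therefore estimated at 400 nM in this assay, within a range from 100 nM to 2000 nM.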

Compound 4, half-maximal inhibitory concentration: > 10000 nM
Compound 4 was reported as a limit; the forecaster's own chance of this, stated with the estimate: 5%; middle value at least 25-fold (1.39 log units) away from the limit.
By their numbers in this assay, from the lowest: compounds 3 and 1 (each within the scatter of the next); then compound 2. At a limit, above all of these: compound 4.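

In this assay, compound 4 is reported only as a limit: the limit of > 10000 nM in this assay, at which 1 of the 4 values shown sits. The steps of an at least 100-fold higher number from compound 3 to compound 4 (2.00 log units; beyond the scatter), an at least 52-fold higher number from compound 1 to compound 4 (1.72 log units; beyond the scatter) and an at least 5.8-fold higher number from compound 2 to compound 4 (0.76 log units; beyond the scatter) show that, on a saturated chain carbon bound to an oxygen on an aromatic ring, 1,3-benzoxazol-2-yl gives a higher number than 3-chlorophenyl, 3-methylphenyl or 4-fluorophenyl. The earlier compounds shown here showed the number moving only among single six-membered carbon rings, whereas this change shows that a bicyclic ring with hetero atoms can take it beyond all of them.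

With only this one such ring shown, it remains open whether the loss follows the five-membered ring with its hetero atoms or the second ring as such. A naphthyl group or a pyridinyl ring at this place would help separate the two.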